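Swapping an Aryl Ether for a Benzoyl Group

The source may hold more compounds than are shown below. What is called first, only, known or untested is meant among the compounds shown, and "the series" means these compounds.

Compound 1 `O=C(Nc1cccc(Oc2nccc(C(F)(F)F)c2Cl)c1)C1CCCN(C(=O)c2cc(C(F)(F)F)cc(C(F)(F)F)c2)C1` was tested in an ADME assay on PC-3 cells (Homo sapiens) for cytotoxicity, read by WST assay, tested at 100 uM (a lower number here means less inhibition, a higher number more inhibition at the concentration tested (going by the name of the read-out)), where compound 1 gives 0%. Compound 3 `O=C(Nc1cccc(Oc2ccccc2)c1)C1CCCN(C(=O)c2cccc(-c3ccco3)c2)C1` gives 0%, level with compound 1 at the digits shown, and compound 2 `O=C(Nc1ccc(Cl)cc1)C1CCCN(C(=O)c2cccc(-c3cccs3)c2)C1` gives 4%; all three numbers sit within the usual scatter of one another, so none can be told apart. Compound 4 `O=C(c1ccccc1)c1cccc(NC(=O)C2CCCN(C(=O)c3cc(C(F)(F)F)cc(C(F)(F)F)c3)C2)c1` is the next compound to consider. Compared with compound 1, the change is benzoyl in place of (3-chloro-4-(trifluoromethyl)pyridin-2-yl)oxy on an aromatic carbon. Among the compounds with values here, no measured pair shows what such a change does here, so no step beyond the scatter is expected from compound 1 to compound 4 in this assay. Compound 4 is expected to give 3%, with a range from 0% to 15%. The expected step is a number 3 percentage points higher from compound 1 to compound 4 (within the scatter).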

Compound 4, a percentage reported as inhibition, at one concentration (the size of the read-out at that concentration, not a potency): 0%
Beside the measured number, compound 4's estimate is 3 percentage points above it; low and high end bracket the measured number.
By their numbers in this assay, from the lowest: compounds 1, 3, 4 and 2 (each within the scatter of the next).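

In this assay, benzoyl in place of (3-chloro-4-(trifluoromethyl)pyridin-2-yl)oxy gives no change at the digits printed from compound 1 to compound 4 (within the scatter). Within the data shown here, as the only pair here that differs in one place, it shows that this aromatic carbon can carry either group with no inhibition step beyond the scatter, even though the ring, its linking atom and its chlorine and fluorine atoms all change. Nothing measured here explains this result. Still open, going by these compounds, is whether an amine, a carboxylic acid or a longer chain at this position would give a reading beyond the scatter.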